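This account rests on a few compounds, and the source may have more. Where it says the series, first, only, none or still open, it means among the compounds named here.

In a functional assay on HepG2 cells (Homo sapiens) for antiproliferative activity, read by MTT assay, with a stated time of 24 h (a lower number here means a stronger inhibitor, a higher number a weaker inhibitor), compound 1 `COc1cc(OC)c(-c2coc3cc(OCc4ccccc4)ccc3c2=O)cc1OC` gives 1320 nM and compound 2 `COc1cc(OC)c(-c2coc3cc(OCc4cccc(F)c4)ccc3c2=O)cc1OC` gives 1230 nM so the two stand level within the usual scatter. Compound 3 `COc1cc(OC)c(-c2coc3cc(OCc4ccc(Cl)cc4)ccc3c2=O)cc1OC` has 4-chlorophenyl in place of 3-fluorophenyl on a saturated chain carbon bound to an oxygen on an aromatic ring. Among the compounds with values here, the only measured step that bears on this, fluoro in place of hydrogen (a 1.1-fold lower number from compound 1 to compound 2 (0.03 log units; within the scatter)), stayed within the scatter, so no shift beyond the scatter is expected, although one step is thin evidence for a new chlorine. In this assay the expected step is therefore small (a 1.0-fold lower number from compound 2 to compound 3 (0.01 log units; within the scatter)). For compound 3 the estimated value is 1200 nM (expected range 550 nM to 2600 nM).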

Compound 3, half-maximal inhibitory concentration: 940 nM
For compound 3 the middle estimate is 1.3-fold (0.11 log units) above the measured one; low and high end bracket the measured number.
By their numbers in this assay, from the lowest: compounds 3, 2 and 1 (each within the scatter of the next).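

In this assay the change from 3-fluorophenyl to 4-chlorophenyl stays within the scatter (a 1.3-fold lower number from compound 2 to compound 3 (0.12 log units; within the scatter)) and so does the step that starts from the compound without a halogen (a 1.4-fold lower number from compound 1 to compound 3 (0.15 log units; within the scatter)). Chlorine therefore joins fluorine as a halogen that leaves the number level at this position, although the first step changes both the halogen and its place on the ring. No measurement at hand explains these results. Still open, on these data alone, is whether an amine or a carboxylic acid on the phenyl group, or a longer chain to it, would shift the number beyond the scatter.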